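Nitrophenyl Swap on a Cytotoxicity-Limited Amide Series

The source may report more compounds than this note shows. Statements on the series, on what has been measured and on what is new or still open speak of the compounds shown alone.

Compound 1 `CC(C)N(Cc1cccc(OCCCCCC(=O)O)c1)C(=O)c1ccc(-c2ccoc2)cc1`: in an ADME assay on Raji cells (Homo sapiens) for cytotoxicity, read by CellTiter-Glo and resazurin assay, with a stated time of 72 h (on this read-out lower numbers stand for an effect already at smaller amounts and higher numbers for an effect only at larger amounts of compound), compound 1 gives > 26000 nM, which is a limit of the assay rather than a number.
Compound 2 `COc1cc(F)cc(-c2ccc(C(=O)N(Cc3cccc(OCCCCCC(=O)O)c3)C(C)C)cc2)c1`: in this assay compound 2 gives > 26000 nM, again a limit of the assay.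

Compound 2 therefore stands at the upper boundary of what this assay can report, and no ranking against compound 1 is possible. Among the compounds with values here, the only measured step, a step that the two limits leave unreadable from compound 1 to compound 2, cannot be sized, because the limit of > 26000 nM in this assay, at which 2 of the 2 values shown sit, shows both values sitting at the same limit.

Compound 3 `CC(C)N(Cc1cccc(OCCCCCC(=O)O)c1)C(=O)c1ccc(-c2cccc([N+](=O)[O-])c2)cc1` differs from compound 2 in one place: 3-nitrophenyl in place of 3-fluoro-5-methoxyphenyl on an aromatic carbon. Within the data shown here, no measured step bears directly on this exchange, and the one step available gives no readable size. The two measured compounds share the same outcome despite a different aryl group on the same aromatic carbon, so compound 3 is expected to behave alike, with the step that the limit leaves unreadable from compound 2 to compound 3 expected to stay within the scatter. Compound 3 is estimated to give 40000 nM in this assay, within 15000 nM to 100000 nM, most likely again reported only as a limit.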

Compound 3, half-maximal effective concentration: > 26000 nM
Compound 3 gave a limit, no number (the forecaster's own chance of this, stated with the estimate: 80%); the middle value lies beyond the limit too.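

No step can be read among compound 1, compound 2 and compound 3 in this assay, because each result is a limit and not a number: the limit of > 26000 nM in this assay, at which 3 of the 3 values shown sit.

The compounds shown leave open whether furan-3-yl, 3-fluoro-5-methoxyphenyl and 3-nitrophenyl differ at all on this read-out, and at what concentration any of the three would show an effect.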